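Adding a Second Fluorine to a Weak Histone Deacetylase 8 Inhibitor

This account rests on a few compounds, and the source may have more. Where it says the series, first, only, none or still open, it means among the compounds named here.

Measured compounds:
- compound 1, `O=C1NC(=O)/C(=C\c2ccc(OCC(=O)N3N=C(c4ccccc4)CC3c3ccccc3)cc2)S1`, 20000 nM
- compound 2, `O=C1NC(=O)/C(=C\c2ccc(OCC(=O)N3N=C(c4ccccc4)CC3c3ccc(F)cc3)cc2)S1`, 26000 nM
- compound 3, `O=C1NC(=O)/C(=C\c2ccc(OCC(=O)N3N=C(c4ccc(F)cc4)CC3c3ccco3)cc2)S1`, with only a limit in this assay

All three were tested in an assay on cells for inhibition of histone deacetylase 8 (Homo sapiens), read by fluorescence, with a stated time of 30 min; a lower number here means a stronger inhibitor, a higher number a weaker inhibitor. Compound 1 gives 20000 nM and compound 2 gives 26000 nM. The two differ by fluoro in place of hydrogen on an aromatic carbon, and this gives a 1.3-fold higher number from compound 1 to compound 2 (0.11 log units; within the scatter). Compound 3 reports only a limit, > 50000 nM, so no number is known for it. How compound 3 differs from compound 1 is not broken down here.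

Compound 4, `O=C1NC(=O)/C(=C\c2ccc(OCC(=O)N3N=C(c4ccc(F)cc4F)CC3c3ccco3)cc2)S1`, has not been measured. It differs from compound 3 by fluoro in place of hydrogen on an aromatic carbon. This is the same kind of change as that from compound 1 to compound 2, but not the same: in the earlier pair the fluoro sits para to a large group, whereas here it sits ortho to a large group and meta to a fluoro group.

The earlier step lies within the usual scatter, so by itself it suggests little movement. Compound 3 is known only as a limit, (the limit of > 50000 nM in this assay, at which 1 of the 3 values shown sits), which means the starting point for compound 4 is itself beyond the number range of this assay. For compound 4 the expected value in this assay is therefore 60000 nM, roughly between 25000 nM and 150000 nM. Put as a step, the expected change from compound 3 to compound 4 is a step that the limit leaves unreadable from compound 3 to compound 4, and it is likely that compound 4 also returns only a limit.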

Compound 4, half-maximal inhibitory concentration: > 50000 nM
Compound 4 ended at the assay's limit; the forecaster's own chance of this, stated with the estimate: 70%; the middle value does not contradict the limit.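

In this assay, compound 3 and compound 4 each return only a limit rather than a number, so no step can be read between them: the limit of > 50000 nM in this assay, at which 2 of the 4 values shown sit. The compounds shown leave open whether 2,4-difluorophenyl in place of 4-fluorophenyl changes the inhibition at all, and whether the added fluoro would have any measurable effect on a compound that gives a number in this assay.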